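Four Biaryl Amides Tested for Toxicity to Skin Cells

The compounds below may be only part of what the source reports. "The series", "measured", "known", "first", "only" and "open" are said of these compounds alone.

Compound 1 `COc1ccc(F)c(-c2ccc(C(=O)N(Cc3cccc(OCCCCCC(=O)O)c3)C(C)C)cc2)c1` is a biaryl amide whose side chain ends in a carboxylic acid. Compound 2 `CC(C)N(Cc1cccc(OCCCCCC(=O)O)c1)C(=O)c1ccc(-c2cccc(F)c2)cc1` keeps that acid chain; the difference from compound 1 is 3-fluorophenyl in place of 2-fluoro-5-methoxyphenyl on an aromatic carbon. Compound 3 `CCOC(=O)CCCCCOc1cccc(CN(C(=O)c2ccc(-c3cc(OC)ccc3F)cc2)C(C)C)c1` differs from compound 1 by ethyl in place of hydrogen on an oxygen next to a carbonyl group, so its core is that of compound 1 with an ester where the acid stood. Compound 4 `CCOC(=O)CCCCCOc1cccc(CN(C(=O)c2ccc(-c3cccc(F)c3)cc2)C(C)C)c1` has not been measured yet.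

In an ADME assay on BJ cells (Homo sapiens) for cytotoxicity, read by CellTiter-Glo and resazurin assay, with a stated time of 72 h (on this read-out lower numbers stand for an effect already at smaller amounts and higher numbers for an effect only at larger amounts of compound), compound 1 reaches only a limit of the assay, > 26000 nM. Compound 2 likewise stops at a limit, > 26000 nM. Compound 3 also gives a limit, > 26000 nM. Because all three values sit at the limit of > 26000 nM in this assay, at which 3 of the 3 values shown sit, the two measured steps cannot be sized: a step that the two limits leave unreadable from compound 1 to compound 2 and a step that the two limits leave unreadable from compound 1 to compound 3.

The change from compound 3 to compound 4 is 3-fluorophenyl in place of 2-fluoro-5-methoxyphenyl on an aromatic carbon, the same change as from compound 1 to compound 2, now made on the ester-bearing core rather than the acid-bearing one.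

Compound 4 is expected to behave like compound 3, with an estimated step that the limit leaves unreadable from compound 3 to compound 4. This expectation rests on the step that the two limits leave unreadable from compound 1 to compound 2, which on the acid core ran from one limit to another. For compound 4 in this assay the expected value is 40000 nM, most likely reported again as a limit, with a range from 20000 nM to 100000 nM.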

Compound 4, half-maximal effective concentration: > 26000 nM
Compound 4: a limit, no number (the forecaster's own chance of this, stated with the estimate: 85%); the middle value lies beyond the limit too.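

In this assay compound 4 gives > 26000 nM, which is a limit and not a number. No size can be read for the new steps from compound 3 to compound 4 or from compound 2 to compound 4, because all the values stop at the same point: the limit of > 26000 nM in this assay, at which 4 of the 4 values shown sit.

The compounds shown leave open whether either change shifts the value at all, and at what concentration, if any, these four compounds would harm the cells.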